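The source may report more compounds than this note shows. Statements on the series, on what has been measured and on what is new or still open speak of the compounds shown alone.

Measured compounds and their values:

compound 1 `Cc1cccc(S(=O)(=O)N2CCC(N3CCC(C)CC3)CC2)c1` — 25 nM
compound 2 `CC1CCN(C2CCN(S(=O)(=O)c3nccn3C)CC2)CC1` — > 5000 nM
compound 3 `CC1CCN(C2CCN(S(=O)(=O)c3cccc(Cl)c3)CC2)CC1` — > 5000 nM

The three compounds share one core and differ only in the group attached to the sulfonyl sulfur. In a functional assay on DLD-1 cells (Homo sapiens) for antiproliferative activity, read by CellTiter-Glo, with a stated time of 72 h (on this read-out lower numbers stand for stronger inhibition and higher numbers for weaker inhibition), compound 1 gives 25 nM. For compound 2 the value > 5000 nM is a limit of this assay, not a number. For compound 3 the value > 5000 nM is likewise a limit. Compound 3 therefore sits at the limit of > 5000 nM in this assay, at which 2 of the 3 values shown sit. Two readable steps bear on the region in question: an at least 200-fold higher number from compound 1 to compound 3 (2.30 log units; beyond the scatter), and an at least 200-fold higher number from compound 1 to compound 2 (2.30 log units; beyond the scatter); the third, a step that the two limits leave unreadable from compound 2 to compound 3, cannot be read.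

Compound 4 `CC1CCN(C2CCN(S(=O)(=O)c3ccc(Br)c(Cl)c3)CC2)CC1` is not yet measured. The change from compound 3 is bromo in place of hydrogen on an aromatic carbon. With compound 3 already at the limit, the step that the limit leaves unreadable from compound 3 to compound 4 is expected to stay small or unreadable. Compound 4 is estimated at 7000 nM, within a range from 2000 nM to 25000 nM.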

Compound 4, half-maximal inhibitory concentration: 12 nM
Compound 4: the middle estimate sits 580-fold (2.77 log units) above what was measured; measured number below the stated range.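

In this assay, placing one bromo on an aromatic carbon para to a large group and ortho to a chloro group turns a compound with no measurable potency into a potent one, giving an at least 410-fold lower number from compound 3 to compound 4 (2.61 log units; beyond the scatter). The sulfonyl aryl group therefore tolerates a chloro group when this bromo is also present, with 4-bromo-3-chlorophenyl giving an at least 410-fold lower number from compound 2 to compound 4 (2.61 log units; beyond the scatter) and, against the 3-methylphenyl compound, a modest gain of a 2.1-fold lower number from compound 1 to compound 4 (0.32 log units; beyond the scatter). The two large steps are only minimum sizes, since compound 2 and compound 3 each rest on a limit of the assay and not on a number: the limit of > 5000 nM in this assay, at which 2 of the 4 values shown sit.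

On these data alone, whether this position needs bromo specifically, or whether fluoro, methoxy or an amine would serve as well, remains open. As far as these compounds go, it is also open whether the bromo would have the same effect without the chloro group.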